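The source may hold more compounds than are shown below. What is called first, only, known or untested is meant among the compounds shown, and "the series" means these compounds.

Of the compounds shown here, three have been measured. In a functional assay on HEK293 cells for agonist activity at Neuronal acetylcholine receptor; alpha4/beta2 (Homo sapiens), read by FLIPR and calcium flux (on this read-out higher numbers stand for an effect only at larger amounts of compound and lower numbers for an effect already at smaller amounts), compound 1 `COc1cc(N2CCCNCC2)cnc1Cl` gives 91.2 nM, and compound 2 `Clc1ncc(N2CCCNCC2)cc1Br` gives 57.5 nM in this assay. These two differ in one place, (methoxy in place of bromo on an aromatic carbon), and that change made a 1.6-fold higher number from compound 2 to compound 1 (0.20 log units; within the scatter). Compound 3 `Brc1cncc(N2CCCNCCC2)c1` gives 182 nM in this assay, the highest of the three numbers; its gap to compound 1 lies within the scatter, while its gap to compound 2 lies beyond it. The difference between the core of compound 3 and the core of compound 2 is not broken down here.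

Compound 4 `COc1cncc(N2CCCNCCC2)c1` has not yet been measured. It differs from compound 3 by methoxy in place of bromo on an aromatic carbon. This is the same kind of change as that from compound 2 to compound 1, not the same: in compound 2 the aromatic carbon is ortho to a chloro group and meta to a group of 7 heavy atoms, whereas in compound 3 it is meta to a group of 8 heavy atoms with no chloro group present. Because the step of a 1.6-fold higher number from compound 2 to compound 1 (0.20 log units; within the scatter) stayed within the scatter, a step of similar size is expected in this assay, namely a 1.4-fold higher number from compound 3 to compound 4 (0.15 log units; within the scatter). Compound 4 is therefore estimated at 260 nM in this assay, with a likely range from 110 nM to 620 nM.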

Compound 4, half-maximal effective concentration: 120 nM
The estimate for compound 4 lay 2.2-fold (0.34 log units) above the measured number; measured number inside the range.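

Replacing bromo with methoxy on the core of compound 3 gave a 1.5-fold lower number from compound 3 to compound 4 (0.18 log units; within the scatter) in this assay. Set beside the earlier case on the other core, neither step nor the gap between the two steps lies beyond the scatter: the same change on two cores in this assay, a 1.6-fold higher number (0.20 log units; within the scatter) from compound 2 to compound 1 and a 1.5-fold lower number (0.18 log units; within the scatter) from compound 3 to compound 4, 2.4-fold (0.38 log units) apart, within the scatter of two such steps

On these two cores, then, the exchange of bromo for methoxy stayed within the scatter each time, and the pair offers no sign that the core alters the outcome of this change, though it does not show that the two steps are truly equal or that the same would hold on any further core.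

The compounds shown leave open how a different group at this place on the ring, such as an amine, a nitrile or a longer ether chain, would compare with bromo and methoxy. They also leave open how much of the difference between the core of compound 2 and the core of compound 3 belongs to the chloro group alone.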